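A few compounds are considered here, and "the series" means these few. Any claim that something is new, unique, unknown or untested is made for them only; others in the source may bear on it.

Compound 1 `COc1ccc(C2N=C(SCc3cccc(Cl)c3)NC(C)=C2C(=O)Nc2ccc(Br)cc2)cc1` and compound 2 `COc1ccc(C2N=C(SCc3ccc(Cl)cc3)NC(C)=C2C(=O)Nc2ccc(Br)cc2)cc1` share a core; compound 3 `CC1=C(C(=O)Nc2ccc([N+](=O)[O-])cc2)C(c2ccc(Br)cc2)N=C(SCc2cccc(Cl)c2)N1` and the unmeasured compound 4 `CC1=C(C(=O)Nc2ccc([N+](=O)[O-])cc2)C(c2ccc(Br)cc2)N=C(SCc2ccc(Cl)cc2)N1` share another, and the difference between the two cores is not broken down here.

In a functional assay on the whole organism (artery, strain albino) with Rattus norvegicus as the target, with a stated time of 360 min, at a dose of 10 mg/kg by the oral route (a higher number here means more inhibition at the dose given (going by the name of the read-out), a lower number less inhibition), compound 1 gives 39.7%, and compound 2 gives 39.2%. The change 4-chlorophenyl in place of 3-chlorophenyl on a saturated chain carbon bound to a sulfur gives a number 0.5 percentage points lower from compound 1 to compound 2 (within the scatter).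

In this assay compound 3 gives 7.2%, beyond the scatter from both compound 1 and compound 2.

Compound 4 carries the same change on the core of compound 3, namely (4-chlorophenyl in place of 3-chlorophenyl on a saturated chain carbon bound to a sulfur). Because a number 0.5 percentage points lower from compound 1 to compound 2 (within the scatter) stayed within the scatter, the step from compound 3 to compound 4 is expected to be about a number 0.2 percentage points lower from compound 3 to compound 4 (within the scatter), also within the scatter. Compound 4 is therefore estimated at 7%, expected between 0% and 18%.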

Compound 4, a percentage reported as inhibition, in the whole organism at one dose (the size of the read-out at that dose, not a potency): 39.2%
For compound 4 the middle estimate is 32.2 percentage points below the measured one, and the stated range ends below it.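

The change to 4-chlorophenyl gives a number 32 percentage points higher from compound 3 to compound 4 (beyond the scatter). In this assay the effect of this change depends on the core, so a step read on one core does not predict the step on the other: the same change on two cores in this assay, a number 0.5 percentage points lower (within the scatter) from compound 1 to compound 2 and a number 32 percentage points higher (beyond the scatter) from compound 3 to compound 4, 32.5 percentage points apart, beyond the scatter of two such steps
This rests on a single pair of steps on two cores that differ in more than one place, and it does not show which of those differences matters or how the change would behave on a third core.

Still open, from the compounds shown here alone, is how this change behaves on a core that differs from either of these in one place only. Also open, going by these compounds, is whether a plain benzyl group or a longer chain on the sulfur would show the same dependence on the core.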